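A few compounds are considered here, and "the series" means these few. Any claim that something is new, unique, unknown or untested is made for them only; others in the source may bear on it.

Compound 1 `C=CC1=C(C(=O)NCCC)C(c2ccc(F)cc2)OC1` is one of three compounds whose cytotoxicity is known here. In a functional assay on HeLa cells (Homo sapiens) for cytotoxicity, read by MTT assay, with a stated time of 24 h (a higher number here means a weaker inhibitor, a lower number a stronger inhibitor), compound 1 gives only a limit of the assay, > 100000 nM, and no number. Compound 2 `C=CC1=C(C(=O)NCC(C)C)C(c2ccc(Cl)c(Cl)c2)OC1` gives 60100 nM in this assay. Compound 3 `C=CC1=C(C(=O)NC2CCCCC2)C(c2ccc(OC)cc2)OC1` gives 24800 nM in this assay. Compound 1 therefore stands at the weak end of what has been measured, at the point where one of the three values sits (the limit of > 100000 nM in this assay, at which 1 of the 3 values shown sits), while the other two compounds give numbers. No two of these three compounds differ in a single place, so no measured step can be read off between them.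

Compound 4 `C=CC1=C(C(=O)Nc2ccccc2)C(c2ccc(F)cc2)OC1` has not yet been measured. It differs from compound 1 in one place: phenyl in place of propyl on an amide-type nitrogen. The change is confined to the amide-type nitrogen, with propylamino becoming anilino and the rest of the shared core untouched. Within the data shown here, no measured pair shows what such a swap does in this assay, and the compounds with numbers differ from compound 1 in more than one place.

The step expected here is an at least 1.6-fold lower number from compound 1 to compound 4 (0.22 log units; that floor lies within the scatter), a modest move toward stronger inhibition that stays within the usual scatter. For compound 4 the expected value in this assay is 60000 nM, with a range from 15000 nM to 200000 nM.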

Compound 4, half-maximal inhibitory concentration: > 100000 nM
Compound 4 ended at the assay's limit; the forecaster's own chance of this, stated with the estimate: 40%; middle value at least 1.6-fold (0.22 log units) away from the limit.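

In this assay compound 4 gives > 100000 nM, a limit and not a number. Compound 1 also gives only a limit, so no step can be read between compound 1 and compound 4: the limit of > 100000 nM in this assay, at which 2 of the 4 values shown sit.

The compounds shown leave open whether phenyl in place of propyl on an amide-type nitrogen changes cytotoxicity at all, and by how much.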